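Swapping the Sulfonyl Substituent: From Cyclopropyl to Acetamidothiazole

The source may hold more compounds than are shown below. What is called first, only, known or untested is meant among the compounds shown, and "the series" means these compounds.

Measured compounds:
- Compound 1, `CCn1c([C@@H](C)NS(=O)(=O)c2ccc(Cl)cc2)nc2cc(CO)ccc21`: 88 mL.min-1.g-1
- Compound 2, `CCn1c(C(C)NS(=O)(=O)c2ccc(Cl)cc2)nc2ccncc21`: 93 mL.min-1.g-1
- Compound 3, `CCn1c([C@@H](C)NS(=O)(=O)C2CC2)nc2ccc(C(F)(F)F)cc21`: < 3 mL.min-1.g-1

These three compounds share a sulfonamide attached to an ethyl-bearing core and were tested in an ADME assay (liver) for metabolic stability, with Liver microsome (Homo sapiens) as the target, read by LC-MS, using microsomes and NADPH, with a stated time of 5 min, at 37 degrees C; on this read-out lower numbers stand for slow clearance and higher numbers for fast clearance. Compound 1 and compound 2 both carry an aromatic group on the sulfonyl sulfur and give the high values shown above. Compound 3 is different: its result is a limit of the assay, not a number, and it sits at the limit of < 3 mL.min-1.g-1 in this assay, at which 1 of the 3 values shown sits, the lowest point any compound here reaches.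

Compound 4, `CCn1c([C@@H](C)NS(=O)(=O)c2cnc(NC(C)=O)s2)nc2ccc(C(F)(F)F)cc21`, has not yet been measured. It differs from compound 3 in one place, (2-acetamido-1,3-thiazol-5-yl in place of cyclopropyl on a sulfonyl sulfur). Among the measured compounds shown here, with no measured step of this kind to lean on, the expectation rests on the observation that compound 1 gives 88 mL.min-1.g-1 and compound 2 gives 93 mL.min-1.g-1 with aromatic sulfonyl groups. Compound 3, by contrast, sits at a limit of the assay rather than at a number. On that basis compound 4 is expected to show a rise beyond the usual scatter, an at least 5.0-fold higher number from compound 3 to compound 4 (0.69 log units; beyond the scatter). Compound 4 is estimated at 15 mL.min-1.g-1, within a range from 3 mL.min-1.g-1 to 60 mL.min-1.g-1.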

Compound 4, intrinsic clearance in microsomes: 15 mL.min-1.g-1
For compound 4 middle estimate and measured number coincide at the digits printed, within the range that was stated.
By their numbers in this assay, from the lowest: compound 4; then compounds 1 and 2 (each within the scatter of the next). At a limit, below all of these: compound 3.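

In this assay, the sulfonyl position clearly affects the read-out: placing 2-acetamido-1,3-thiazol-5-yl in place of cyclopropyl on a sulfonyl sulfur gives an at least 5.0-fold higher number from compound 3 to compound 4 (0.69 log units; beyond the scatter). This is the only pair shown that differs in one place, whereas compound 1 and compound 2 each differ from compound 3 in more than one, so the change can now be followed on its own. Compound 3 stands at a limit of the assay and not at a number, so the real step may be larger than the printed one: the limit of < 3 mL.min-1.g-1 in this assay, at which 1 of the 4 values shown sits.

The thiazole ring and the acetamido group enter together, and the compounds shown do not tell which of the two accounts for the rise. A plain 1,3-thiazol-5-yl or a 2-amino-1,3-thiazol-5-yl group on the same sulfur could begin to separate them.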